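Nitro for Cyano on a Sulfone Core

The compounds below may be only part of what the source reports. "The series", "measured", "known", "first", "only" and "open" are said of these compounds alone.

Compound 1 `CC(O)(CSc1cccc(S(F)(F)(F)(F)F)c1)C(=O)Nc1ccc(C#N)cc1C(F)(F)F`: 17600 nM
Compound 2 `CC(O)(CSc1cccc(S(F)(F)(F)(F)F)c1)C(=O)Nc1ccc([N+](=O)[O-])cc1C(F)(F)F`: 12700 nM
Compound 3 `CC(O)(CS(=O)(=O)c1ccc(S(F)(F)(F)(F)F)cc1)C(=O)Nc1ccc(C#N)cc1C(F)(F)F`: 17800 nM

These three compounds were tested in a functional assay on LNCaP cells (Homo sapiens) for antiproliferative activity, read by propidium iodide staining, with a stated time of 96 h; on this read-out lower numbers stand for stronger inhibition and higher numbers for weaker inhibition. Compound 2 differs from compound 1 by nitro in place of cyano on an aromatic carbon, and this change made a 1.4-fold lower number from compound 1 to compound 2 (0.14 log units; within the scatter). Compound 3 carries a different core; how its core differs from that of compound 1 is not broken down here. For the measured compounds named here, compound 4 `CC(O)(CS(=O)(=O)c1ccc(S(F)(F)(F)(F)F)cc1)C(=O)Nc1ccc([N+](=O)[O-])cc1C(F)(F)F` differs from compound 3 by nitro in place of cyano on an aromatic carbon, the same change as the one from compound 1 to compound 2. For this assay a step of the same small size is expected, a 1.4-fold lower number from compound 3 to compound 4 (0.14 log units; within the scatter), because a 1.4-fold lower number from compound 1 to compound 2 (0.14 log units; within the scatter) stayed within the scatter, and the values of compound 3 and compound 1 lie within the scatter of each other. Compound 4 is therefore estimated at about 13000 nM, most likely between 6500 nM and 26000 nM.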

Compound 4, half-maximal inhibitory concentration: 12500 nM
Estimate against measurement, compound 4: 1.0-fold (0.02 log units) above, and the stated range covers the measured number.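

On the core of compound 3, nitro in place of cyano gave a 1.4-fold lower number from compound 3 to compound 4 (0.15 log units; within the scatter) in this assay. Set beside the same change on the core of compound 1, the two steps agree: the same change on two cores in this assay, a 1.4-fold lower number (0.14 log units; within the scatter) from compound 1 to compound 2 and a 1.4-fold lower number (0.15 log units; within the scatter) from compound 3 to compound 4, 1.0-fold (0.01 log units) apart, within the scatter of two such steps. This shows that on these two cores the change left the result within the ordinary spread of repeat measurements, but it does not separate nitro from cyano, and two cores cannot show that the change would stay this small across the whole series.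

The compounds shown leave open what an amine or a carboxylic acid would do on that same aromatic carbon. They also leave open whether the step stays this small on a third core.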